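Compound 3: tert-butoxycarbonyl in place of the oxadiazolyl group

The compounds below may be only part of what the source reports. "The series", "measured", "known", "first", "only" and "open" are said of these compounds alone.

Compound 2 `CCN(CC)S(=O)(=O)c1ccc(S(=O)(=O)N2CCC[C@@H](C(=O)N3CCN(c4nc(C(C)C)no4)CC3)C2)cc1` gives 50 nM in a functional assay on MIA PaCa-2 cells (Homo sapiens) for inhibition, read by MTT assay, with a stated time of 7 days (a lower number here means a stronger inhibitor, a higher number a weaker inhibitor), and stands lowest of the two numbers in hand. Compound 1 `CCN(CC)S(=O)(=O)c1ccc(S(=O)(=O)N2CCC[C@@H](C(=O)N3CCN(c4nc(C(F)(F)F)no4)CC3)C2)cc1` gives 600 nM in this assay. Within the data shown here, the only measured step, a 12-fold lower number from compound 1 to compound 2 (1.08 log units; beyond the scatter), shows that what sits on the five-membered ring matters. Compound 3 `CCN(CC)S(=O)(=O)c1ccc(S(=O)(=O)N2CCC[C@@H](C(=O)N3CCN(C(=O)OC(C)(C)C)CC3)C2)cc1` differs from compound 2 by tert-butoxycarbonyl in place of 3-isopropyl-1,2,4-oxadiazol-5-yl on an amine nitrogen in a ring. Among the measured compounds shown here, no measured step removes the whole ring, so that step bears only indirectly. A move toward a higher number in this assay is expected, a 20-fold higher number from compound 2 to compound 3 (1.30 log units; beyond the scatter), with wide uncertainty. Compound 3 is estimated at 1000 nM, within a range from 150 nM to 8000 nM.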

Compound 3, half-maximal inhibitory concentration: 70 nM
Beside the measured number, compound 3's estimate is 14-fold (1.15 log units) above it; measured number outside the range, below it.
By their numbers in this assay, from the lowest: compounds 2 and 3 (each within the scatter of the next); then compound 1.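

On the amine nitrogen in the six-membered ring, a group with no ring can stand in for the aromatic five-membered ring in this assay: tert-butoxycarbonyl in place of 3-isopropyl-1,2,4-oxadiazol-5-yl gives a 1.4-fold higher number from compound 2 to compound 3 (0.15 log units; within the scatter) and leaves the two groups indistinguishable. Set against the trifluoromethyl-bearing group, the same tert-butoxycarbonyl gives an 8.6-fold lower number from compound 1 to compound 3 (0.93 log units; beyond the scatter) and so leaves compound 1 alone at the high end of these three. No data at hand offer an explanation for either step.
Open, on these data alone, is whether the bare amine, or a small acetyl group on that nitrogen, would stay level with compound 3. Also open, as far as these compounds go, is whether a bulky alkyl group without a carbonyl, such as tert-butyl, would do the same.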